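Amide variation on the shared core

This account rests on a few compounds, and the source may have more. Where it says the series, first, only, none or still open, it means among the compounds named here.

Compound 1 `CN1[C@@H]2c3[nH]c4ccccc4c3C[C@H]1[C@H](C#N)N1[C@@H](CNC(=O)c3ccc(Cl)cc3)c3[nH]c4ccccc4c3C[C@@H]21` gives 350 nM in a functional assay on HepG2 cells (Homo sapiens) for cytotoxicity, read by MTT assay, with a stated time of 72 h; on this read-out higher numbers stand for weaker inhibition and lower numbers for stronger inhibition. Within the data shown here, compound 2 `CN1[C@@H]2c3[nH]c4ccccc4c3C[C@H]1[C@H](C#N)N1[C@@H](CNC(=O)c3ccc4ccccc4n3)c3[nH]c4ccccc4c3C[C@@H]21` gives 110 nM in this assay, the lowest of the two numbers so far; the step of a 3.2-fold lower number from compound 1 to compound 2 (0.50 log units; beyond the scatter) lies beyond the scatter. Compound 3 `CN1[C@@H]2c3[nH]c4ccccc4c3C[C@H]1[C@H](C#N)N1[C@@H](CNC(=O)/C=C/c3cccc(C(F)(F)F)c3)c3[nH]c4ccccc4c3C[C@@H]21` carries 2-(3-(trifluoromethyl)phenyl)ethenyl in place of quinolin-2-yl on a carbonyl carbon. Among the measured compounds shown here, only the step from compound 1 to compound 2 bears on this position: it swapped the group on the carbonyl carbon and shifted the number modestly, so a further shift of similar size in either direction is plausible, with the direction not fixed by what is known. Compound 3 is expected to give 200 nM, in the range 70 nM to 600 nM, an expected step of a 1.8-fold higher number from compound 2 to compound 3 (0.26 log units; within the scatter).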

Compound 3, half-maximal inhibitory concentration: 540 nM
Compound 3: middle estimate off by 2.7-fold (0.43 log units), on the low side; the range from low to high includes it.
By their numbers in this assay, from the lowest: compound 2; then compounds 1 and 3 (each within the scatter of the next).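

In this assay the 2-(3-(trifluoromethyl)phenyl)ethenyl group does not keep what quinolin-2-yl gave on this carbonyl carbon, with a 4.9-fold higher number from compound 2 to compound 3 (0.69 log units; beyond the scatter) beyond the scatter. Against 4-chlorophenyl the same group shows a 1.5-fold higher number from compound 1 to compound 3 (0.19 log units; within the scatter) and no separation, so among these three groups only quinolin-2-yl stands apart. No evidence on hand accounts for these differences.

Open, going by these compounds, is whether the ring nitrogen of quinolin-2-yl or its second ring carries the difference; pyridin-2-yl and naphthalen-2-yl on the carbonyl carbon would separate the two.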